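Pyridin-2-yl Amide on a Shared Core: Expected Maximal Response

The source may report more compounds than this note shows. Statements on the series, on what has been measured and on what is new or still open speak of the compounds shown alone.

Three compounds built on one shared core have been measured in a functional assay on HEK293 cells for positive allosteric modulation of metabotropic glutamate receptor 5 (Homo sapiens), read by calcium flux; a lower number here means a smaller maximal response, a higher number a larger maximal response:

Compound 1, `CC(C)(C)C(=O)N1CCCn2nc(COc3ccccc3)cc21`, gives 64%.
Compound 2, `O=C(c1ccccc1)N1CCCn2nc(COc3ccccc3)cc21`, gives 63%.
Compound 3, `O=C(c1ccc(F)cc1)N1CCCn2nc(COc3ccccc3)cc21`, gives 63%.

Compound 3 stands level with compound 2 at the digits printed, and its distance from compound 1 is small: a number 1 percentage points lower from compound 1 to compound 3 (within the scatter). The other two steps among the measured compounds are of the same kind, a number 1 percentage points lower from compound 1 to compound 2 (within the scatter) and no change at the digits printed from compound 2 to compound 3 (within the scatter). Across the three, the group on the carbonyl carbon has gone from tert-butyl to phenyl to 4-fluorophenyl without any step beyond the scatter, so within this series the maximal response has so far been insensitive to that group.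

Compound 4, `O=C(c1ccccn1)N1CCCn2nc(COc3ccccc3)cc21`, differs from compound 3 in one place: pyridin-2-yl in place of 4-fluorophenyl on a carbonyl carbon. For the measured compounds named here, no measured step exchanges an aromatic carbon for a ring nitrogen at this position, so the only guides are the three steps above, all within the scatter. On that basis compound 4 is expected to give in this assay a maximal response of 62%, with a range from 48% to 76%. The step this estimate implies, a number 1 percentage points lower from compound 3 to compound 4 (within the scatter), is expected to stay within the scatter.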

Compound 4, largest response reached (reported as percent of maximum), in percent of the reference or control that the assay uses: 44%
Compound 4: middle estimate off by 18 percentage points, on the high side, and the stated range ends above it.
By their numbers in this assay, from the lowest: compound 4; then compounds 2, 3 and 1 (each within the scatter of the next).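

In this assay the group on the carbonyl carbon proves not to be indifferent after all: pyridin-2-yl in place of 4-fluorophenyl gives a number 19 percentage points lower from compound 3 to compound 4 (beyond the scatter), and the matching exchanges give a number 19 percentage points lower from compound 2 to compound 4 (beyond the scatter) and a number 20 percentage points lower from compound 1 to compound 4 (beyond the scatter). Tert-butyl, phenyl and 4-fluorophenyl stand within the scatter of one another, so the earlier compounds showed only that these three groups could be exchanged without a clear change in the largest response; compound 4 shows that this does not extend to every aromatic ring at this position, and that a single ring nitrogen, with the hydrogen-bond acceptor counted for pyridin-2-yl, accompanies a step beyond the scatter. Nothing available here explains why the largest response falls with this exchange.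

As far as these compounds go, what remains open is whether pyridin-3-yl or pyridin-4-yl on the same carbonyl carbon would stand with compound 4 or with compound 3. From the compounds shown here alone, it is also open whether a pyrimidin-2-yl ring, with a second ring nitrogen, would give a still smaller maximal response.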